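The source may hold more compounds than are shown below. What is called first, only, known or untested is meant among the compounds shown, and "the series" means these compounds.

Measured compounds:
compound 1 `CC1CCN(C2CCN(S(=O)(=O)c3cccc(N)c3)CC2)CC1`, 3400 nM
compound 2 `COc1ccc(-c2cccc(S(=O)(=O)N3CCC(N4CCC(C)CC4)CC3)c2)cc1`, 23 nM

In a functional assay on DLD-1 cells (Homo sapiens) for antiproliferative activity, read by CellTiter-Glo, with a stated time of 72 h (on this read-out lower numbers stand for stronger inhibition and higher numbers for weaker inhibition), compound 1 stands highest of the two numbers; its nearest neighbour is compound 2, reached by a 150-fold lower number from compound 1 to compound 2 (2.17 log units; beyond the scatter). Compound 3 `CC1CCN(C2CCN(S(=O)(=O)c3ccc(Cl)c(Cl)c3)CC2)CC1` changes compound 1 by 3,4-dichlorophenyl in place of 3-aminophenyl on a sulfonyl sulfur. Among the compounds with values here, the only measured step, a 150-fold lower number from compound 1 to compound 2 (2.17 log units; beyond the scatter), also removes the amino group and was large, but a different group enters there, so it bears on this change only loosely. From compound 1 a lower number is therefore expected for compound 3, a step of an 8.5-fold lower number from compound 1 to compound 3 (0.93 log units; beyond the scatter), smaller than the measured one. For compound 3 the estimate is 400 nM, with a range from 80 nM to 2000 nM.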

Compound 3, half-maximal inhibitory concentration: 2.9 nM
For compound 3 the middle estimate is 140-fold (2.14 log units) above the measured one, outside the stated range (below it).
By their numbers in this assay, from the lowest: compound 3; then compound 2; then compound 1.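

Swapping 3-aminophenyl for 3,4-dichlorophenyl on the sulfonyl sulfur gives a 1200-fold lower number from compound 1 to compound 3 (3.07 log units; beyond the scatter) in this assay. A low number at this position therefore does not need the second aromatic ring of compound 2: the entering group keeps one six-membered aromatic ring of carbon only and has no hydrogen-bond donors. Nothing available explains why this change has so large an effect. As far as these compounds go, whether both chlorines are needed stays open, and so does how a single chlorine, a plain phenyl or a trifluoromethyl group on the ring would compare.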